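Bromo in Place of Methoxy: Expected Cytotoxicity Outcome

The source may report more compounds than this note shows. Statements on the series, on what has been measured and on what is new or still open speak of the compounds shown alone.

Compound 1 `COc1ccc(Nc2nc(-n3cnc4ccccc43)cs2)cc1` was examined in a functional assay on RKO cells (Homo sapiens) for cytotoxicity, read by resazurin assay, with a stated time of 72 h; on this read-out higher numbers stand for weaker inhibition and lower numbers for stronger inhibition. In this assay compound 1 reaches only the assay limit, > 100000 nM, so no number is known for it. Compound 2 `Cc1nccn1-c1csc(Nc2ccccc2)n1` likewise shows only a limit in this assay, > 100000 nM. Both results sit at the same boundary (the limit of > 100000 nM in this assay, at which 2 of the 2 values shown sit), so compound 1 stands where every measured value stands, with nothing resolved beneath it. Compound 3 `Brc1ccc(Nc2nc(-n3cnc4ccccc43)cs2)cc1` has not yet been measured in this assay; it differs from compound 1 by bromo in place of methoxy on an aromatic carbon. Going by the values given here, no step between measured compounds exists to show a direction, and both known values are limits. The change expected in this assay is a step that the limit leaves unreadable from compound 1 to compound 3, which amounts to none beyond the scatter. Compound 3 is therefore estimated at 150000 nM, with a range from 30000 nM to 600000 nM, and is most likely to be reported once more only as a limit.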

Compound 3, half-maximal inhibitory concentration: > 100000 nM
Compound 3: a limit, no number (the forecaster's own chance of this, stated with the estimate: 80%); the middle value lies beyond the limit too.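

No step can be read between compound 1 and compound 3, as both give only a limit and the exchange of methoxy for bromo stays unresolved: the limit of > 100000 nM in this assay, at which 3 of the 3 values shown sit.

The compounds shown leave open how any change to the shared core would register in this assay, where none of them has a number.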